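Cyano to hydrogen across two related cores

The source may report more compounds than this note shows. Statements on the series, on what has been measured and on what is new or still open speak of the compounds shown alone.

Compound 1 `COc1ccc2c(c1)c(-c1cc(C(F)(F)F)c(C#N)c(-c3cn(S(=O)(=O)c4ccc(C)cc4)c4ccc(OC)cc34)n1)cn2S(=O)(=O)c1ccc(C)cc1` and compound 2 `COc1ccc2c(-c3cc(C(F)(F)F)c(C#N)c(-c4cn(S(=O)(=O)c5ccc(C)cc5)c5cc(OC)ccc45)n3)cn(S(=O)(=O)c3ccc(C)cc3)c2c1` are built from the same atoms joined differently; the difference between the two cores is not broken down here. In a functional assay on A549 cells (Homo sapiens) for inhibition, tested at 1 uM (a lower number here means a weaker effect, a higher number a stronger effect of the compound at the concentration tested), compound 1 gives 24.4% and compound 2 gives 26.7%; the two numbers lie within the usual scatter of each other, so no order between them is read from this pair. Compound 3 `COc1ccc2c(c1)c(-c1cc(C(F)(F)F)cc(-c3cn(S(=O)(=O)c4ccc(C)cc4)c4ccc(OC)cc34)n1)cn2S(=O)(=O)c1ccc(C)cc1` carries the core of compound 1 with one change, (hydrogen in place of cyano on an aromatic carbon). In this assay compound 3 gives 7.1%. Within the data shown here, the step of a number 17.3 percentage points lower from compound 1 to compound 3 (beyond the scatter) is the only measured step in the set and shows the loss of the cyano group as a modest but real loss of inhibition.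

Compound 4 `COc1ccc2c(-c3cc(C(F)(F)F)cc(-c4cn(S(=O)(=O)c5ccc(C)cc5)c5cc(OC)ccc45)n3)cn(S(=O)(=O)c3ccc(C)cc3)c2c1` is not yet measured. It stands to compound 2 as compound 3 stands to compound 1: hydrogen in place of cyano on an aromatic carbon. The place of the change is described in the same words for both pairs, so it is taken as the same change carried onto the other core. The expected step of a number 17.7 percentage points lower from compound 2 to compound 4 (beyond the scatter) is estimated at about the size of the earlier one. Among the measured compounds shown here, this expectation rests on the single measured step of a number 17.3 percentage points lower from compound 1 to compound 3 (beyond the scatter), with no second instance in the set to test how far the core matters. Compound 4 is expected to give 9% in this assay, with a range estimated from 0% to 20%.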

Compound 4, a percentage reported as inhibition, at one concentration (the size of the read-out at that concentration, not a potency): 35.5%
The estimate for compound 4 lay 26.5 percentage points below the measured number; the whole stated range lies below it.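

In this assay, hydrogen in place of cyano on the core of compound 2 gives a number 8.8 percentage points higher from compound 2 to compound 4 (within the scatter), so the loss of inhibition seen on the core of compound 1 does not recur on this core. The effect of this change therefore does not carry from one of these two cores to the other, and the step measured on one core is a poor guide to the step on the other: the same change on two cores in this assay, a number 17.3 percentage points lower (beyond the scatter) from compound 1 to compound 3 and a number 8.8 percentage points higher (within the scatter) from compound 2 to compound 4, 26.1 percentage points apart, beyond the scatter of two such steps

Among these compounds, with only one step on each core, and with each read-out taken at one concentration and so not a potency, these data do not show which feature of the cores sets the difference, and they say nothing about how the change would behave on any further core.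

On both cores, the compounds shown leave open what a primary amide, a carboxylic acid or an amine would do on the aromatic carbon ortho to a trifluoromethyl group, where only cyano and hydrogen appear. Also open, on these data alone, is whether the split between the two cores would persist with a methyl group or a chlorine atom in place of the methoxy groups.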